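The compounds below may be only part of what the source reports. "The series", "measured", "known", "first", "only" and "open" are said of these compounds alone.

Measured in a functional assay on MCF7 cells (Homo sapiens) for inhibition, read by MTT assay; on this read-out higher numbers stand for weaker inhibition and lower numbers for stronger inhibition:
compound 1 `COc1cc2ncnc(Nc3ccc(NC(=O)c4cccc(C)c4)cc3)c2cc1OC` gives 13000 nM
compound 2 `COc1cc2ncnc(Nc3ccc(NC(=O)c4ccc(C(C)(C)C)cc4)cc3)c2cc1OC` gives > 100000 nM (a limit of the assay, not a number)
compound 3 `COc1cc2ncnc(Nc3ccc(NC(=O)c4ccccc4F)cc3)c2cc1OC` gives 11000 nM

Going by the values given here, compound 1 holds one of only two actual numbers. The other belongs to compound 3, and a 1.2-fold lower number from compound 1 to compound 3 (0.07 log units; within the scatter) stays within the scatter.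

The next comparison is compound 4 `COc1cc2ncnc(Nc3ccc(NC(=O)c4ccc(F)cc4)cc3)c2cc1OC`, which differs from compound 1 by 4-fluorophenyl in place of 3-methylphenyl on a carbonyl carbon and carries 4-fluorophenyl in place of 3-methylphenyl on a carbonyl carbon. Two measured steps exchange the group at this same place. The nearer guide is a 1.2-fold lower number from compound 1 to compound 3 (0.07 log units; within the scatter), which also brings in a fluorophenyl group. The other, an at least 7.6-fold higher number from compound 1 to compound 2 (0.88 log units; beyond the scatter), ends at a limit and brings in 4-(tert-butyl)phenyl, a group that compound 4 lacks. It is a reason only to keep the upper end of the range wide.

No change beyond the scatter is expected, and the estimate is a 1.1-fold lower number from compound 1 to compound 4 (0.03 log units; within the scatter) in this assay. For compound 4 the estimated value is 12000 nM, with an expected range of 5000 nM to 40000 nM.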

Compound 4, half-maximal inhibitory concentration: 27000 nM
For compound 4 the middle estimate is 2.3-fold (0.35 log units) below the measured one; low and high end bracket the measured number.
By their numbers in this assay, from the lowest: compounds 3 and 1 (each within the scatter of the next); then compound 4. At a limit, above all of these: compound 2.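

Fluorophenyl groups on this carbonyl carbon are not interchangeable in this assay: 4-fluorophenyl in place of 2-fluorophenyl gives a 2.5-fold higher number from compound 3 to compound 4 (0.39 log units; beyond the scatter). 4-Fluorophenyl in place of 3-methylphenyl gives a 2.1-fold higher number from compound 1 to compound 4 (0.32 log units; beyond the scatter), whereas compound 3 and compound 1 lie within the scatter of each other, so a fluorophenyl group as such does not guarantee a match with 3-methylphenyl. Fluoro in place of tert-butyl on an aromatic carbon gives an at least 3.7-fold lower number from compound 2 to compound 4 (0.56 log units; beyond the scatter), a step that starts from a limit of the assay and not a number, so its full size stays unknown: the limit of > 100000 nM in this assay, at which 1 of the 4 values shown sits.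

Still open, going by these compounds, is where a phenyl group carrying an amine or a carboxylic acid would fall at this carbonyl carbon. Also open, on these data alone, is how a longer chain in place of the aromatic ring would read.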